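Terminal amine variants at the chain end: compound 4

The source may report more compounds than this note shows. Statements on the series, on what has been measured and on what is new or still open speak of the compounds shown alone.

Measured so far in a functional assay on MCF7 cells (Homo sapiens) for antiproliferative activity; on this read-out lower numbers stand for stronger inhibition and higher numbers for weaker inhibition:
compound 1 `CC(C)=CCc1cc(C(=O)Nc2cc3ccc(OCCC4CCCCN4)c(C)c3oc2=O)ccc1O`: 710 nM
compound 2 `CC(C)=CCc1cc(C(=O)Nc2cc3ccc(OCCCN4CCCC4)c(C)c3oc2=O)ccc1O`: 990 nM
compound 3 `CCN(CC)CCCOc1ccc2cc(NC(=O)c3ccc(O)c(CC=C(C)C)c3)c(=O)oc2c1C`: 6390 nM

Compound 1 holds the lowest of the three numbers in this assay; compound 2 lies within the scatter of it, whereas compound 3 is clearly weaker. Compound 4 `CC(C)=CCc1cc(C(=O)Nc2cc3ccc(OCCCNC(C)(C)C)c(C)c3oc2=O)ccc1O` alters compound 1 only at the chain end: ((tert-butyl)amino)methyl in place of piperidin-2-yl on a saturated chain carbon, two bonds along the chain from an oxygen on an aromatic ring. For the measured compounds named here, two measured steps bear on this position. a 1.4-fold higher number from compound 1 to compound 2 (0.14 log units; within the scatter) shows that a ring-to-ring exchange there stays within the scatter, while a 9.0-fold higher number from compound 1 to compound 3 (0.95 log units; beyond the scatter) and a 6.5-fold higher number from compound 2 to compound 3 (0.81 log units; beyond the scatter) show that going to an acyclic amine brings a modest rise in the number. The group entering in compound 4 is likewise acyclic, so a modest rise is expected, tempered by the retained hydrogen-bond donor. Compound 4 is therefore estimated at 2000 nM (range 700 nM to 6000 nM), a step of a 2.8-fold higher number from compound 1 to compound 4 (0.45 log units; beyond the scatter).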

Compound 4, half-maximal inhibitory concentration: 950 nM
Compound 4: middle estimate off by 2.1-fold (0.32 log units), on the high side; the range from low to high includes it.
By their numbers in this assay, from the lowest: compounds 1, 4 and 2 (each within the scatter of the next); then compound 3.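

In this assay, an open-chain amine at the chain end does not by itself raise the number: a 1.3-fold higher number from compound 1 to compound 4 (0.13 log units; within the scatter) and a 1.0-fold lower number from compound 2 to compound 4 (0.02 log units; within the scatter) place (tert-butyl)amino level with both ring amines. Against this, a 6.7-fold lower number from compound 3 to compound 4 (0.83 log units; beyond the scatter) leaves compound 3 as the only one of the four set apart, so the earlier rise holds for diethylamino and not for open-chain amines in general. No evidence bearing on the reason is available.

Open, on these data alone, is whether dimethylamino would sit with diethylamino or with (tert-butyl)amino, and whether a morpholin-4-yl end would stay level with the ring amines.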